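Exposure after an oral dose: swapping cyclobutyl for thiazolyl

A few compounds are considered here, and "the series" means these few. Any claim that something is new, unique, unknown or untested is made for them only; others in the source may bear on it.

The measured compounds and their values:
- compound 1, `Cc1nc(N)nc(N[C@@H]2C[C@H](CO)[C@@H](O)[C@H]2O)c1-c1nc2ccccc2s1`: 1820 ng.h/mL
- compound 2, `CCNc1nc(C)c(-c2nc3ccccc3s2)c(N[C@@H]2C[C@H](CO)[C@@H](O)[C@H]2O)n1`: 2580 ng.h/mL
- compound 3, `Cc1nc(NCC2CCC2)nc(N[C@@H]2C[C@H](CO)[C@@H](O)[C@H]2O)c1-c1nc2ccccc2s1`: 228 ng.h/mL

These three compounds share one core and differ only in what sits on one nitrogen on an aromatic ring. In an ADME assay on the whole organism (plasma) for pharmacokinetics, with Rattus norvegicus as the target, with a stated time of 6 h, at a dose of 10 mg/kg by the oral route (a higher number here means more compound in the circulation at the dose given, a lower number less compound in the circulation), compound 3 gives the lowest of the three numbers, and both of its gaps to the others lie beyond the scatter: an 8.0-fold lower number from compound 1 to compound 3 (0.90 log units; beyond the scatter) and an 11-fold lower number from compound 2 to compound 3 (1.05 log units; beyond the scatter). Compound 1 and compound 2, by contrast, sit close together, as a 1.4-fold higher number from compound 1 to compound 2 (0.15 log units; within the scatter) shows.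

Compound 4, `Cc1nc(NCc2nccs2)nc(N[C@@H]2C[C@H](CO)[C@@H](O)[C@H]2O)c1-c1nc2ccccc2s1`, has not been measured in this assay. It differs from compound 3 in one place: 1,3-thiazol-2-yl in place of cyclobutyl on a saturated chain carbon bound to a nitrogen on an aromatic ring. Within the data shown here, no measured step covers this swap directly; the two steps that lead into compound 3 both describe adding or enlarging the group on that nitrogen, and both lowered the number. Compound 4 keeps a group of similar size on the same saturated chain carbon, so a number near that of compound 3 is expected, with wide uncertainty in either direction. The estimate for compound 4 is 400 ng.h/mL, between 100 ng.h/mL and 1500 ng.h/mL, which is expected to be a 1.8-fold higher number from compound 3 to compound 4 (0.24 log units; within the scatter).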

Compound 4, area under the concentration-time curve: 242 ng.h/mL
Compound 4: the middle estimate sits 1.7-fold (0.22 log units) above what was measured, within the range that was stated.
By their numbers in this assay, from the lowest: compounds 3 and 4 (each within the scatter of the next); then compounds 1 and 2 (each within the scatter of the next).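

Swapping the ring on this saturated chain carbon leaves the number in this assay unchanged within the scatter (a 1.1-fold higher number from compound 3 to compound 4 (0.03 log units; within the scatter)), even though a non-aromatic ring of carbon only gives way to an aromatic ring carrying nitrogen and sulfur, with hydrogen-bond acceptors that cyclobutyl lacks. The low exposure of compound 3 is therefore not unique to cyclobutylmethyl, since (1,3-thiazol-2-yl)methyl also falls well short of the hydrogen of compound 1 (a 7.5-fold lower number from compound 1 to compound 4 (0.88 log units; beyond the scatter)) and the ethyl of compound 2 (an 11-fold lower number from compound 2 to compound 4 (1.03 log units; beyond the scatter)), so among these four compounds both ring-bearing groups give low numbers and neither small group does. Nothing available explains either the shared low level or the absence of a difference between the two rings.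

These compounds cannot show whether the number depends on having a ring at all or simply on the size of the group on the nitrogen, a question that a plain propyl or butyl chain could address. They also leave open whether an amine or a carboxylic acid on the same saturated chain carbon would stay at this low level or return to the level of compound 1 and compound 2.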